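This account rests on a few compounds, and the source may have more. Where it says the series, first, only, none or still open, it means among the compounds named here.

Measured compounds:
- compound 1, `O=C(NCc1ccc(S(=O)(=O)c2cccc(C(F)(F)F)c2)cc1)N1Cc2ccncc2C1`: 14 mL/min/kg
- compound 2, `O=C(NCc1ccc(S(=O)(=O)N2CC3(CCOCC3)C2)cc1)N1Cc2ccncc2C1`: 13 mL/min/kg

In an ADME assay on microsomes from liver (Homo sapiens) for pharmacokinetics, read by LC-MS, with a stated time of 60 min, tested at 1 uM (on this read-out higher numbers stand for fast clearance and lower numbers for slow clearance), compound 1 stands highest of the two numbers shown, with compound 2 nearest; the gap runs a 1.1-fold lower number from compound 1 to compound 2 (0.03 log units; within the scatter), so the two sit together. Compound 3, `O=C(NCc1ccc(S(=O)(=O)N2CCC(N3CCCC3)CC2)cc1)N1Cc2ccncc2C1`, differs from compound 1 in one place: 4-(pyrrolidin-1-yl)piperidin-1-yl in place of 3-(trifluoromethyl)phenyl on a sulfonyl sulfur. Within the data shown here, only one measured step bears on this change, the one that also swaps out the 3-(trifluoromethyl)phenyl on the sulfonyl sulfur for a pair of non-aromatic rings, and that step came to a 1.1-fold lower number from compound 1 to compound 2 (0.03 log units; within the scatter), a shift within the scatter. Among the measured compounds shown here, the group entering compound 3 is not the same as that in compound 2, so the comparison is loose, but the one available step gives no reason to expect a change beyond the scatter in this assay. Compound 3 is therefore expected to land near compound 1, with an estimated step of a 1.1-fold higher number from compound 1 to compound 3 (0.03 log units; within the scatter). For compound 3 the estimate is 15 mL/min/kg, spanning 7 mL/min/kg to 32 mL/min/kg.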

Compound 3, clearance: 6 mL/min/kg
Beside the measured number, compound 3's estimate is 2.5-fold (0.40 log units) above it; measured number below the stated range.
By their numbers in this assay, from the lowest: compound 3; then compounds 2 and 1 (each within the scatter of the next).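

The group on the sulfonyl sulfur can move clearance after all: in this assay the 4-(pyrrolidin-1-yl)piperidin-1-yl group brings a 2.3-fold lower number from compound 1 to compound 3 (0.37 log units; beyond the scatter) and also a 2.2-fold lower number from compound 2 to compound 3 (0.34 log units; beyond the scatter), both modest but real shifts. The earlier swap gave only a 1.1-fold lower number from compound 1 to compound 2 (0.03 log units; within the scatter), so replacing the 3-(trifluoromethyl)phenyl ring with non-aromatic rings does not by itself lower the number; which non-aromatic group sits on the sulfur matters. No measurement shown here explains the lower clearance of compound 3.

As far as these compounds go, it remains open which part of the entering group carries the shift. A plain piperidin-1-yl group, or a dimethylamino group in place of the pyrrolidine ring, would help separate the contribution of each part.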